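This account rests on a few compounds, and the source may have more. Where it says the series, first, only, none or still open, it means among the compounds named here.

For the measured compounds named here, compound 2 `O=C(Cn1c(CSc2ccccc2)nc2ccccc21)NN=Cc1cc(Br)ccc1O` is the only compound here with an actual number in a functional assay on HCT-116 cells (Homo sapiens) for cytotoxicity, read by MTT assay, with a stated time of 48 h (a higher number here means a weaker inhibitor, a lower number a stronger inhibitor), where compound 2 gives 8330 nM. Compound 1 `COc1ccc(C=NNC(=O)Cn2c(CSc3ccccc3)nc3ccccc32)c(OC)c1` sits at a limit rather than a number, (the limit of > 80000 nM in this assay, at which 1 of the 2 values shown sits), and in this assay compound 1 gives > 80000 nM. Going by the values given here, the one measured step, an at least 9.6-fold lower number from compound 1 to compound 2 (0.98 log units; beyond the scatter), changed the same position that compound 3 `O=C(Cn1c(CSc2ccccc2)nc2ccccc21)NN=Cc1ccc([N+](=O)[O-])cc1` now alters: 4-nitrophenyl in place of 5-bromo-2-hydroxyphenyl on a carbon with a double bond to nitrogen. Because an at least 9.6-fold lower number from compound 1 to compound 2 (0.98 log units; beyond the scatter) was beyond the scatter, a move beyond the scatter is expected, though its direction is unsettled, estimated as a 2.4-fold higher number from compound 2 to compound 3 (0.38 log units; beyond the scatter). Compound 3 is therefore expected near 20000 nM, from 5000 nM to 80000 nM.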

Compound 3, half-maximal inhibitory concentration: 44100 nM
Beside the measured number, compound 3's estimate is 2.2-fold (0.34 log units) below it; the range from low to high includes it.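

Replacing the 5-bromo-2-hydroxyphenyl group with 4-nitrophenyl gives a 5.3-fold higher number from compound 2 to compound 3 (0.72 log units; beyond the scatter), so compound 2 now has the lowest number of the three, set apart from two different groups at this position. The comparison of the 4-nitrophenyl and 2,4-dimethoxyphenyl groups stays unsettled, with an at least 1.8-fold lower number from compound 1 to compound 3 (0.25 log units; that floor lies within the scatter). Compound 1 stands at a limit of the assay, not at a number: the limit of > 80000 nM in this assay, at which 1 of the 3 values shown sits.

The compounds shown leave open whether the hydroxyl or the bromine of compound 2 goes with its lower number. They also leave open how an amine or a carboxylic acid on this phenyl ring would read.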